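A few compounds are considered here, and "the series" means these few. Any claim that something is new, unique, unknown or untested is made for them only; others in the source may bear on it.

Measured in a functional assay on the whole organism with Mus musculus as the target, in the maximal electroshock model, with a stated time of 4 h; on this read-out lower numbers stand for an effect already at smaller amounts and higher numbers for an effect only at larger amounts of compound:

Compound 1 `O=C(Nc1nc2ccc(Cl)cc2s1)c1ccccc1C(=O)c1ccccc1`: 100 mg/kg
Compound 2 `O=C(Nc1nc2ccc(F)cc2s1)c1ccccc1C(=O)c1ccccc1`: 100 mg/kg
Compound 3 `CC(=O)c1ccc2nc(NC(=O)c3ccccc3C(=O)c3ccccc3)sc2c1`: 300 mg/kg

Compound 2 stands level with compound 1 at the digits shown, and together they give the lowest number; compound 3 lies higher, by a 3.0-fold higher number from compound 2 to compound 3 (0.48 log units; beyond the scatter). Compound 4 `O=C(Nc1nc2cc(Cl)c(F)cc2s1)c1ccccc1C(=O)c1ccccc1` differs from compound 2 by one change: chloro in place of hydrogen on an aromatic carbon. Going by the values given here, no measured step puts a second group onto this ring, so the comparison rests on the single-group steps. The step of no change at the digits printed from compound 1 to compound 2 (within the scatter) shows that exchanging chloro for fluoro left the number unchanged, while a 3.0-fold higher number from compound 2 to compound 3 (0.48 log units; beyond the scatter) shows a modest rise when acetyl entered. Because no change at the digits printed from compound 1 to compound 2 (within the scatter) is flat, adding chloro is expected to give no step beyond the scatter, no change at the digits printed from compound 2 to compound 4 (within the scatter). Compound 4 is therefore estimated at 100 mg/kg, most likely between 50 mg/kg and 300 mg/kg.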

Compound 4, minimum effective dose: 300 mg/kg
For compound 4 the middle estimate is 3.0-fold (0.48 log units) below the measured one; measured number inside the range.
By their numbers in this assay, from the lowest: compounds 1 and 2 (each within the scatter of the next); then compounds 3 and 4 (each within the scatter of the next).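

In this assay, going by these compounds alone, the earlier compounds all carry hydrogen at this ring position, and replacing that hydrogen with chloro gives a 3.0-fold higher number from compound 2 to compound 4 (0.48 log units; beyond the scatter). So this position responds to substitution, even though exchanging chloro for fluoro at the neighbouring site gave no change at the digits printed from compound 1 to compound 2 (within the scatter). No measurement here accounts for the rise.

As far as these compounds go, whether the rise belongs to chloro itself or to any added group at this position stays open. From the compounds shown here alone, it is also open whether it depends on the fluoro group, and a methyl group or an amine here could begin to separate these possibilities.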